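Swapping the ester group on a shared core

The source may hold more compounds than are shown below. What is called first, only, known or untested is meant among the compounds shown, and "the series" means these compounds.

Measured compounds: compound 1 `C=C1CC[C@@H]2[C@](C)(COC(=O)/C=C/c3ccccc3)[C@H](O)CC[C@@]2(C)[C@@H]1C/C=C1\C=COC1=O` with 271000 nM in an ADME assay on HepG2 2.2.15 cells (Homo sapiens) for cytotoxicity, read by MTT assay; a lower number here means that less compound is tolerated, a higher number that more compound is tolerated; compound 2 `C=C1CC[C@@H]2[C@](C)(COC(=O)c3cccs3)[C@H](O)CC[C@@]2(C)[C@@H]1C/C=C1\C=COC1=O` with 2470000 nM in this assay.

Among the measured compounds shown here, compound 2 gives the highest of the two numbers, and the one step measured so far is a 9.1-fold higher number from compound 1 to compound 2 (0.96 log units; beyond the scatter). Compound 3 `C=C1CC[C@@H]2[C@](C)(COC(=O)CCCC)[C@H](O)CC[C@@]2(C)[C@@H]1C/C=C1\C=COC1=O` carries the change (butyl in place of thiophen-2-yl on a carbonyl carbon). For the measured compounds named here, no measured step involves butyl, so the step from compound 1 to compound 2 bears on this only by sharing the place of change, not the groups. The step is therefore expected to stay within the scatter, and compound 3 is estimated at 2000000 nM (range 700000 nM to 6000000 nM), a step of a 1.2-fold lower number from compound 2 to compound 3 (0.09 log units; within the scatter).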

Compound 3, half-maximal cytotoxic concentration: 225000 nM
Estimate against measurement, compound 3: 8.9-fold (0.95 log units) above; measured number below the stated range.
By their numbers in this assay, from the lowest: compounds 3 and 1 (each within the scatter of the next); then compound 2.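

In this assay the group on this carbonyl carbon can move the number in either direction: butyl gives an 11-fold lower number from compound 2 to compound 3 (1.04 log units; beyond the scatter), yet a 1.2-fold lower number from compound 1 to compound 3 (0.08 log units; within the scatter). So compound 2, with thiophen-2-yl, stands apart, and carrying an aromatic ring is not enough to set it apart, as compound 1 also has one. Nothing measured here explains why thiophen-2-yl differs.

Still open, from the compounds shown here alone, is whether another ring, such as furan-2-yl or plain phenyl, would behave like thiophen-2-yl. Also open, going by these compounds, is what a chain longer than butyl, or one ending in an amine, would give.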